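Working notes on a four-compound set

This account rests on a few compounds, and the source may have more. Where it says the series, first, only, none or still open, it means among the compounds named here.

Measured so far in a functional assay on HT-29 cells (Homo sapiens) for antiproliferative activity, read by MTT assay, with a stated time of 72 h; a higher number here means a weaker inhibitor, a lower number a stronger inhibitor:
compound 1, `CN(C)CCn1cnnc1-c1cc(Oc2ccc(NC(=O)Nc3ccccc3C(F)(F)F)cc2F)ccn1`, gives 5860 nM
compound 2, `CN(C)CCn1cnnc1-c1cc(Oc2ccc(NC(=O)Nc3ccc(F)c(F)c3)cc2F)ccn1`, gives 3620 nM
compound 3, `CCN(CC)CCn1cnnc1-c1cc(Oc2ccc(NC(=O)Nc3ccccc3C(F)(F)F)cc2F)ccn1`, gives 3410 nM

Compound 2 differs from compound 1 by 3,4-difluorophenyl in place of 2-(trifluoromethyl)phenyl on an amide-type nitrogen. This gave a 1.6-fold lower number from compound 1 to compound 2 (0.21 log units; within the scatter). Compound 3 differs from compound 1 by diethylamino in place of dimethylamino on a saturated chain carbon, two bonds along the chain from an aromatic nitrogen. This gave a 1.7-fold lower number from compound 1 to compound 3 (0.24 log units; within the scatter). For the measured compounds named here, no step is computed between compound 2 and compound 3; their two numbers lie within the scatter of each other, so nothing is said about their order.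

Compound 4, `CCN(CC)CCn1cnnc1-c1cc(Oc2ccc(NC(=O)Nc3ccc(F)c(F)c3)cc2F)ccn1`, is not yet measured. It differs from compound 3 by 3,4-difluorophenyl in place of 2-(trifluoromethyl)phenyl on an amide-type nitrogen. Going by the values given here, this is the same change as the one made from compound 1 to compound 2, and the place is described in the same words, so it is taken as the same change. The two cores differ by diethylamino in place of dimethylamino on a saturated chain carbon, two bonds along the chain from an aromatic nitrogen.

For compound 4 a step of about a 1.6-fold lower number from compound 3 to compound 4 (0.19 log units; within the scatter) in this assay is expected, beside the earlier one, a 1.6-fold lower number from compound 1 to compound 2 (0.21 log units; within the scatter). This rests on compound 3 at 3410 nM and on that single earlier instance, which lay within the scatter, so the direction is not secure. Compound 4 is estimated at 2200 nM, between 900 nM and 5500 nM.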

Compound 4, half-maximal inhibitory concentration: 1240 nM
Beside the measured number, compound 4's estimate is 1.8-fold (0.25 log units) above it; the measured number falls inside the stated range.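

In this assay, 3,4-difluorophenyl in place of 2-(trifluoromethyl)phenyl on the amide-type nitrogen gives a 2.8-fold lower number from compound 3 to compound 4 (0.44 log units; beyond the scatter), and diethylamino in place of dimethylamino gives a 2.9-fold lower number from compound 2 to compound 4 (0.47 log units; beyond the scatter). Each change points the same way on both cores, and the two instances of the aryl change are not separated in size: the same change on two cores in this assay, a 1.6-fold lower number (0.21 log units; within the scatter) from compound 1 to compound 2 and a 2.8-fold lower number (0.44 log units; beyond the scatter) from compound 3 to compound 4, 1.7-fold (0.23 log units) apart, within the scatter of two such steps. For the compounds shown here, the same holds for the amine change, but the earlier instance of each change lies within the scatter and each change is seen on only two cores, so the four compounds show consistency in direction, not a general rule or a true difference in step size: the same change on two cores in this assay, a 1.7-fold lower number (0.24 log units; within the scatter) from compound 1 to compound 3 and a 2.9-fold lower number (0.47 log units; beyond the scatter) from compound 2 to compound 4, 1.7-fold (0.23 log units) apart, within the scatter of two such steps.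

The compounds shown leave open whether the aryl change carries over to a side chain ending in a primary amine, or to a longer chain between the aromatic nitrogen and the amine. They also leave open where an unsubstituted phenyl on the amide-type nitrogen would fall in this assay.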